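A few compounds are considered here, and "the series" means these few. Any claim that something is new, unique, unknown or untested is made for them only; others in the source may bear on it.

The three measured relatives share one core and differ only in the group on an oxygen on a saturated carbon. In a functional assay with Homo sapiens as the target (on this read-out lower numbers stand for stronger inhibition and higher numbers for weaker inhibition), compound 1 `CC(C)[C@H](NC(=O)COc1cccc2ccccc12)C(=O)N[C@@H](CC(=O)O)C(=O)COC(=O)c1c(Cl)cccc1Cl` gives 11500 nM as its reading. Compound 2 `CC(C)[C@H](NC(=O)COc1cccc2ccccc12)C(=O)N[C@@H](CC(=O)O)C(=O)COc1cc(F)ccc1F` gives 19700 nM and compound 3 `CC(C)[C@H](NC(=O)COc1cccc2ccccc12)C(=O)N[C@@H](CC(=O)O)C(=O)COc1ccc(F)c(F)c1F` gives 20600 nM on the same read-out. Compound 3 cannot be ranked against the other two: a 1.0-fold higher number from compound 2 to compound 3 (0.02 log units; within the scatter) and a 1.8-fold higher number from compound 1 to compound 3 (0.25 log units; within the scatter) are both within the scatter.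

Compound 4 `CC(C)[C@H](NC(=O)COc1cccc2ccccc12)C(=O)N[C@@H](CC(=O)O)C(=O)COc1c(Cl)cccc1Cl` differs from compound 3 in one place (2,6-dichlorophenyl in place of 2,3,4-trifluorophenyl on an oxygen on a saturated carbon), with 2,6-dichlorophenyl in place of 2,3,4-trifluorophenyl on an oxygen on a saturated carbon. Among the compounds with values here, no measured compound carries this group directly on that oxygen, though compound 1 holds it through a carbonyl. The closest evidence is the exchange of one fluorinated phenyl for another, where a 1.0-fold higher number from compound 2 to compound 3 (0.02 log units; within the scatter) stays small, and a 1.7-fold higher number from compound 1 to compound 2 (0.23 log units; within the scatter) is just as modest. No step beyond the scatter is therefore expected in this assay here. The estimated step is a 1.3-fold lower number from compound 3 to compound 4 (0.11 log units; within the scatter) and it is expected to stay within the scatter. For compound 4 the estimate is 16000 nM with an expected range from 7000 nM to 35000 nM for now.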

Compound 4, half-maximal inhibitory concentration: 15300 nM
Estimate against measurement, compound 4: 1.0-fold (0.02 log units) above, within the range that was stated.
By their numbers in this assay, from the lowest: compounds 1, 4, 2 and 3 (each within the scatter of the next).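

With the 2,6-dichlorophenyl group, chlorine now stands on the phenyl ring on this oxygen where the earlier ethers carried fluorine, and in this assay this exchange stays within the scatter, with a 1.3-fold lower number from compound 3 to compound 4 (0.13 log units; within the scatter) and a 1.3-fold lower number from compound 2 to compound 4 (0.11 log units; within the scatter) as the two steps. Within the data shown here, compound 4 also allows the first like-for-like look at the carbonyl, since the same dichlorophenyl group without it gives a 1.3-fold higher number from compound 1 to compound 4 (0.12 log units; within the scatter) and so no separation from the ester. No measurement is available here to explain why these four readings stay so close.

Every group shown on this oxygen carries a chlorinated or fluorinated phenyl ring. As far as these compounds go, whether an amine, a carboxylic acid or a longer chain at this place would move the reading beyond the scatter remains open.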